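The source may hold more compounds than are shown below. What is called first, only, known or untested is meant among the compounds shown, and "the series" means these compounds.

In a functional assay on FM3A cells (Mus musculus) for antiproliferative activity, read by cell counting, with a stated time of 2 days (a higher number here means a weaker inhibitor, a lower number a stronger inhibitor), compound 1 `COc1ccc(C(=O)c2sc(N3CCCC3)nc2N)cc1` gives > 200000 nM, which is a limit of the assay and not a number. Compound 2 `COc1cccc(C(=O)c2sc(N3CCCC3)nc2N)c1` gives > 200000 nM, also a limit. Compound 3 `Nc1nc(N2CCCC2)sc1C(=O)c1ccc(Br)cc1` gives > 200000 nM, again only a limit. All three therefore stand at the same mark: the limit of > 200000 nM in this assay, at which 3 of the 3 values shown sit. Compound 4 `Nc1nc(N2CCCC2)sc1C(=O)c1ccccc1` has hydrogen in place of bromo on an aromatic carbon, para to a large group: hydrogen in place of bromo on an aromatic carbon. Among the compounds with values here, one measured step bears on this change, also a swap on an aromatic carbon: a step that the two limits leave unreadable from compound 1 to compound 3. It offers no size to carry over, so no step beyond the scatter is expected in this assay. The expected change is a number no higher from compound 3 to compound 4 (the limit leaves the size open). Compound 4 is estimated at 200000 nM, with an expected range of 70000 nM to 400000 nM.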

Compound 4, half-maximal inhibitory concentration: > 200000 nM
Compound 4 was reported as a limit; the forecaster's own chance of this, stated with the estimate: 80%; the middle value sits exactly at the limit.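

Compound 4 is again reported only as a limit, so its steps from compound 1, compound 2 and compound 3 cannot be read: the limit of > 200000 nM in this assay, at which 4 of the 4 values shown sit. In this assay the compounds shown leave open which change to the shared core, if any, would give a readable number.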